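The compounds below may be only part of what the source reports. "The series", "measured", "known", "first", "only" and "open" are said of these compounds alone.

In a functional assay on FaDu cells (Homo sapiens) for cytotoxicity, read by MTT assay, with a stated time of 72 h (on this read-out higher numbers stand for lower toxicity in this test and lower numbers for higher toxicity in this test), compound 1 `COc1nsc(NC(=O)C(=O)c2cn(C(C)C)c3ccccc23)n1` gives 10400 nM. Among the two compounds with a number in this assay, compound 1 stands highest, meaning it was the less toxic of the two. The nearest is compound 2 `COCCc1cc(C(=O)C(=O)Nc2ccc(OC(F)(F)F)cc2)c2ccccn12`, which in this assay gives 758 nM, a gap beyond the usual scatter. Compound 3 `COc1ccc(NC(=O)C(=O)c2cn(C(C)C)c3cccnc23)cn1` is reported only at a limit, > 10000 nM in this assay, not as a number; this is the case described by the limit of > 10000 nM in this assay, at which 1 of the 3 values shown sits.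

Compound 4 `COc1ccc(NC(=O)C(=O)c2cn(C(C)C)c3ccccc23)nn1` has not yet been measured. It differs from compound 1 in one place: 6-methoxypyridazin-3-yl in place of 3-methoxy-1,2,4-thiadiazol-5-yl on an amide-type nitrogen.

Among the compounds with values here, no measured pair differs by this same change, so its effect is unknown. The step from compound 1 to compound 4 in this assay is expected to be small, with no direction beyond the scatter: a 1.2-fold lower number from compound 1 to compound 4 (0.06 log units; within the scatter). For compound 4 the value in this assay is therefore estimated at about 9000 nM, in a range from 3000 nM to 27000 nM.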

Compound 4, concentration lethal to 50% of the cells: 2270 nM
For compound 4 the middle estimate is 4.0-fold (0.60 log units) above the measured one; the whole stated range lies above it.
By their numbers in this assay, from the lowest: compound 2; then compound 4; then compound 1.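

The group on the amide-type nitrogen matters in this assay: placing 6-methoxypyridazin-3-yl where 3-methoxy-1,2,4-thiadiazol-5-yl stood gives a 4.6-fold lower number from compound 1 to compound 4 (0.66 log units; beyond the scatter), so compound 4 is the more toxic of this pair. Within the data shown here, the earlier compounds differ from one another in more than one place, so this is the first direct reading of a change at this position, though it rests on a single pair. Nothing measured here explains the step.

The compounds shown leave open whether the step follows from the change in the ring itself, and whether it would hold on a different core. Also open, on these data alone, is how an amine or a carboxylic acid in place of the methoxy group would read in this assay.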